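The source may report more compounds than this note shows. Statements on the series, on what has been measured and on what is new or still open speak of the compounds shown alone.

Of the compounds shown here, three sharing one core have been measured in an ADME assay on AGS cells (Homo sapiens) for cytotoxicity, read by neutral red uptake, with a stated time of 24 h; a lower number here means a stronger inhibitor, a higher number a weaker inhibitor. Compound 1 `CC(=O)Oc1c(C(C)C)cc2c3c1OC(=O)[C@@]31CCCC(C)(C)[C@@H]1CC2` gives 275000 nM. Compound 2 `CCCCCCCCCCCCCCCC(=O)Oc1c(C(C)C)cc2c3c1OC(=O)[C@@]31CCCC(C)(C)[C@@H]1CC2` reaches only a limit of the assay, > 1000000 nM, and not a number. Compound 3 `CC(C)c1cc2c3c(c1OC(=O)Cc1c[nH]c4ccccc14)OC(=O)[C@@]31CCCC(C)(C)[C@@H]1CC2` gives 85600 nM, the lowest of the two actual numbers.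

Compound 4 `CC(C)c1cc2c3c(c1OC(=O)CCCc1c[nH]c4ccccc14)OC(=O)[C@@]31CCCC(C)(C)[C@@H]1CC2` differs from compound 3 in one place, on a saturated chain carbon bound to a carbonyl carbon: 2-(1H-indol-3-yl)ethyl in place of 1H-indol-3-yl on a saturated chain carbon bound to a carbonyl carbon. In words, 2-(1H-indol-3-yl)ethyl stands in place of 1H-indol-3-yl, which can also be read as (1H-indol-3-yl)methyl going to 3-(1H-indol-3-yl)propyl. The indole stays and only the chain grows.

Among the measured compounds shown here, the one measured step that bears on this is a 3.2-fold lower number from compound 1 to compound 3 (0.51 log units; beyond the scatter), which introduced the 1H-indol-3-yl group and was modest in size. For the measured compounds named here, no measured pair tests chain length with the indole kept, and compound 2 offers only a limit, so it fixes no size. A small step with no firm direction is therefore expected in this assay, and the expected change is a 1.2-fold higher number from compound 3 to compound 4 (0.07 log units; within the scatter). For compound 4 the estimate is 100000 nM, with an expected range from 40000 nM to 250000 nM.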

Compound 4, half-maximal inhibitory concentration: 46800 nM
The estimate for compound 4 lay 2.1-fold (0.33 log units) above the measured number; the measured number falls inside the stated range.
By their numbers in this assay, from the lowest: compounds 4 and 3 (each within the scatter of the next); then compound 1. At a limit, above all of these: compound 2.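

In this assay, among the compounds shown here, a 1.8-fold lower number from compound 3 to compound 4 (0.26 log units; within the scatter) is the first test of chain length with the indole kept, and it shows that 2-(1H-indol-3-yl)ethyl and 1H-indol-3-yl cannot be told apart at this position. Set against the plain hydrogen at the same saturated chain carbon, however, 2-(1H-indol-3-yl)ethyl gives a 5.9-fold lower number from compound 1 to compound 4 (0.77 log units; beyond the scatter), so the chain bearing the indole holds a separation from compound 1 that lies beyond the scatter. The large step of an at least 21-fold lower number from compound 2 to compound 4 (1.32 log units; beyond the scatter), with 1H-indol-3-yl in place of dodecyl, shows that the group at the chain end matters more here than chain length alone, although this step is only a bound, and compound 2 stands at a limit and not at a number: the limit of > 1000000 nM in this assay, at which 1 of the 4 values shown sits.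

The compounds shown leave open whether a longer chain ending in the indole would separate from compound 4, since the single step in chain length stays within the scatter. They also leave open whether the indole itself is needed, or whether a phenyl ring or an amine at the end of the same chain would give a similar number.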